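This account rests on a few compounds, and the source may have more. Where it says the series, first, only, none or still open, it means among the compounds named here.

Measured in a functional assay on KG-1 cells (Homo sapiens) for antiproliferative activity (a higher number here means that more compound is needed for the effect, a lower number that less compound is needed), so far:
- compound 1, `CN1CC(C#Cc2c(Cl)c3c(Cl)cc(C(N)=O)nc3n2[C@H]2CCCNC2)CC1=O`: 155 nM
- compound 2, `CC(O)C#Cc1c(Cl)c2c(Cl)cc(C(N)=O)nc2n1[C@H]1CCCNC1`: 147 nM
- compound 3, `NC(=O)c1cc(Cl)c2c(Cl)c(C#CC3CCOCC3)n([C@H]3CCCNC3)c2n1`: 69 nM

Compound 3 stands lowest of the three numbers. Its nearest neighbour is compound 2, with a 2.1-fold lower number from compound 2 to compound 3 (0.33 log units; beyond the scatter), and the furthest is compound 1, with a 2.2-fold lower number from compound 1 to compound 3 (0.35 log units; beyond the scatter); both steps are beyond the scatter but modest. Compound 1 and compound 2 sit within the scatter of each other, as a 1.1-fold lower number from compound 1 to compound 2 (0.02 log units; within the scatter) shows.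

Compound 4, `CC(C)(CC#Cc1c(Cl)c2c(Cl)cc(C(N)=O)nc2n1[C@H]1CCCNC1)C(N)=O`, is not yet measured. It differs from compound 3 in one place: 2-carbamoyl-2-methylpropyl in place of oxan-4-yl on a triple-bonded carbon. The two steps that bear on this are the two leading into compound 3: replacing 1-methyl-5-oxopyrrolidin-3-yl gave a 2.2-fold lower number from compound 1 to compound 3 (0.35 log units; beyond the scatter), and replacing 1-hydroxyethyl gave a 2.1-fold lower number from compound 2 to compound 3 (0.33 log units; beyond the scatter). In both cases the oxan-4-yl compound came out with the lower number, and the two groups that were left behind, one ring-bearing and one open-chain, gave numbers within the scatter of each other. The entering 2-carbamoyl-2-methylpropyl is another substituted group without a ring, so a modest step back upward in this assay, of about the size seen in those two steps, is expected rather than none.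

Compound 4 is therefore estimated at 130 nM, with a range of 55 nM to 300 nM, which means an expected step of a 1.9-fold higher number from compound 3 to compound 4 (0.28 log units; within the scatter).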

Compound 4, half-maximal effective concentration: 269 nM
For compound 4 the middle estimate is 2.1-fold (0.32 log units) below the measured one; the range from low to high includes it.
By their numbers in this assay, from the lowest: compound 3; then compounds 2, 1 and 4 (each within the scatter of the next).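

In this assay, within the data shown here, the largest step so far at this triple-bonded carbon is a 3.9-fold higher number from compound 3 to compound 4 (0.59 log units; beyond the scatter), so exchanging oxan-4-yl for 2-carbamoyl-2-methylpropyl, an open-chain group with a hydrogen-bond donor, gives up the lowest number in the set, though the step is still modest. The new group does not separate from the other two groups, as a 1.8-fold higher number from compound 2 to compound 4 (0.26 log units; within the scatter) and a 1.7-fold higher number from compound 1 to compound 4 (0.24 log units; within the scatter) show, so compound 3 alone stands apart among the four, and the ring-bearing compound 1 goes against any reading that a ring on its own is enough. No measurement at hand bears on why oxan-4-yl differs from these three groups.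

Still open, as far as these compounds go, is which part of oxan-4-yl matters, which a cyclohexyl group, a piperidin-4-yl amine or a smaller ring such as oxetan-3-yl would help to separate in this assay. The compounds shown also leave apart the two parts of 2-carbamoyl-2-methylpropyl, so a simple tert-butyl group, a carboxylic acid in place of the primary amide, or a longer chain carrying that amide remain untested comparisons in this set.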